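Fluorine on the Phenyl Ring of Compound 2

The compounds below may be only part of what the source reports. "The series", "measured", "known", "first", "only" and "open" are said of these compounds alone.

The measured compounds:
compound 1, `Cc1nn(C)c2c1C(c1ccccc1)=NCC(=O)N2`: 10 mg/kg
compound 2, `CCc1nn(C)c2c1C(c1ccccc1)=NCC(=O)N2`: 2.5 mg/kg

In a functional assay on the whole organism (strain Holtzman) with Rattus norvegicus as the target (a lower number here means that less compound is needed, a higher number that more compound is needed for the effect), compound 1 gives 10 mg/kg. Among the measured compounds shown here, compound 2 gives 2.5 mg/kg in this assay, and the one step measured so far is a 4.0-fold lower number from compound 1 to compound 2 (0.60 log units; beyond the scatter), which places compound 2 at the lowest of the two numbers, with compound 1 as its only neighbour. Compound 3, `CCc1nn(C)c2c1C(c1ccc(F)cc1)=NCC(=O)N2`, keeps the ethyl of compound 2 and differs from it in a single place: fluoro in place of hydrogen on an aromatic carbon. For the measured compounds named here, no measured step bears on this part of the structure; the only step known, from compound 1 to compound 2, changes the chain on the core and says nothing about the phenyl ring. With nothing to point in either direction, the change is expected to leave the number of compound 2 within the scatter, which means an expected step of no change at the digits printed from compound 2 to compound 3 (within the scatter). Compound 3 is therefore estimated at 2.5 mg/kg in this assay, with a range from 1 mg/kg to 6 mg/kg.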

Compound 3, minimum effective dose: > 40 mg/kg
Compound 3: a limit, no number (the forecaster's own chance of this, stated with the estimate: 5%); at least 16-fold (1.20 log units) between middle value and limit.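

In this assay compound 3 gives > 40 mg/kg, which is a limit of the assay and not a number. Among the compounds shown here, the phenyl ring, which no earlier step touched, proves far from silent: fluoro in place of hydrogen on an aromatic carbon, para to a large group, gives an at least 16-fold higher number from compound 2 to compound 3 (1.20 log units; beyond the scatter), whereas the only earlier step, a change in the chain on the core, gave a 4.0-fold lower number from compound 1 to compound 2 (0.60 log units; beyond the scatter). A single fluorine at this place is thus enough to carry the number out of the measured range, so the true size of the step remains unknown and the printed size is only a bound: the limit of > 40 mg/kg in this assay, at which 1 of the 3 values shown sits.

The compounds shown leave open whether this sensitivity belongs to fluoro alone or to any replacement of hydrogen at this place, as chloro, methoxy and hydroxyl on the same carbon are not among them. They also leave open whether a longer chain on the core, such as propyl in place of the ethyl, would lower the number further than compound 2 does.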